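The source may hold more compounds than are shown below. What is called first, only, known or untested is meant among the compounds shown, and "the series" means these compounds.

Measured so far in a functional assay on MDA-MB-231 cells (Homo sapiens) for cytotoxicity, read by MTT assay, with a stated time of 48 h, in the presence of a further agent that is not named here; on this read-out lower numbers stand for stronger inhibition and higher numbers for weaker inhibition:
compound 1 `O=C(NCc1ccccc1)c1csc(-c2c[nH]c3ccccc23)n1` gives > 100000 nM.
compound 2 `COc1ccc(NC(=O)c2csc(-c3cn(Cc4ccc(Cl)cc4)c4ccccc34)n2)cc1` gives > 100000 nM.
compound 3 `COc1cc(NC(=O)c2csc(-c3c[nH]c4ccc(Br)cc34)n2)cc(OC)c1OC` gives > 100000 nM.

The value for compound 1 is a limit of the assay, not a number. The value for compound 2 is likewise a limit. The value for compound 3 is a limit too. Going by the values given here, all three readings sit at the limit of > 100000 nM in this assay, at which 3 of the 3 values shown sit, so compound 1 cannot be placed against the other two by any measured number, and no step between measured compounds is available for this series.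

Compound 4 `Cc1ccc(NC(=O)c2csc(-c3c[nH]c4ccccc34)n2)cc1` is not yet measured in this assay. It differs from compound 1 in one place: 4-methylphenyl in place of benzyl on an amide-type nitrogen, in words 4-methylphenyl in place of benzyl on an amide-type nitrogen. Since compound 1 gives only > 100000 nM, no movement beyond the scatter is expected from this change. The step from compound 1 to compound 4 is expected to be a number no higher from compound 1 to compound 4 (the limit leaves the size open), that is none beyond the scatter. Compound 4 is expected to read at 100000 nM, with a range from 30000 nM to 300000 nM, most probably again as a limit rather than a number.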

Compound 4, half-maximal inhibitory concentration: > 100000 nM
Compound 4 was reported as a limit (the forecaster's own chance of this, stated with the estimate: 85%); the middle value sits exactly at the limit.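

In this assay compound 4 gives > 100000 nM, which is a limit. Compound 1 is also held at a limit, so no step can be read from compound 1 to compound 4. The compounds shown leave open which change to the shared core or its substituents, if any, would give a measurable value: the limit of > 100000 nM in this assay, at which 4 of the 4 values shown sit.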